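A few compounds are considered here, and "the series" means these few. Any claim that something is new, unique, unknown or untested is made for them only; others in the source may bear on it.

In a functional assay on LFCl2A cells (Rattus norvegicus) for cytotoxicity (on this read-out lower numbers stand for stronger inhibition and higher numbers for weaker inhibition), compound 1 `CC/C=C\C/C=C\C/C=C\C/C=C\C/C=C\C/C=C\CCC(=O)OC[C@H]1O[C@H](C2CCCC=C2C)C=CC1=O` gives 20 nM, the lower of the two numbers available, while compound 2 `O=C1C=C[C@@H](CO)O[C@@H]1CC1=CCCCC1` gives 9500 nM. Compound 3 `CC/C=C\C/C=C\C/C=C\C/C=C\C/C=C\C/C=C\CCC(=O)OC[C@H]1O[C@H](CC2=CCCCC2)C=CC1=O` has the same atoms as compound 1, joined differently: (cyclohex-1-en-1-yl)methyl in place of 2-methylcyclohex-2-en-1-yl on a saturated ring carbon. In short, it carries (cyclohex-1-en-1-yl)methyl in place of 2-methylcyclohex-2-en-1-yl on a saturated ring carbon. For the measured compounds named here, no measured step in this assay isolates this change, so only a modest move towards weaker inhibition is expected, with the estimated step being a 2.0-fold higher number from compound 1 to compound 3 (0.30 log units; within the scatter). Compound 3 is estimated at 40 nM, within an expected range of 10 nM to 200 nM.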

Compound 3, half-maximal inhibitory concentration: 50 nM
Compound 3: middle estimate off by 1.3-fold (0.10 log units), on the low side; the range from low to high includes it.
By their numbers in this assay, from the lowest: compound 1; then compound 3; then compound 2.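

In this assay, putting (cyclohex-1-en-1-yl)methyl in place of 2-methylcyclohex-2-en-1-yl on a saturated ring carbon gives a 2.5-fold higher number from compound 1 to compound 3 (0.40 log units; beyond the scatter) and so a modest move towards weaker inhibition. This shows that the position responds to how the same atoms are joined, even with the ring and the double bond count kept. No available evidence bears on why the number moves.

Still open, going by these compounds, is whether an amine or a carboxylic acid at this position would be tolerated on the core of compound 1. Also open, on these data alone, is how a longer open chain in place of either ring group would compare.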